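A few compounds are considered here, and "the series" means these few. Any claim that something is new, unique, unknown or untested is made for them only; others in the source may bear on it.

The measured compounds:

Compound 1, `O=C1O[C@@H](CN2CCCCC2)CN1c1ccc(-n2cc(-c3ccccn3)cn2)c(F)c1`. In an ADME assay on HEK293-A cells (Homo sapiens) for cytotoxicity, read by MTT assay, with a stated time of 48 h (a lower number here means a stronger inhibitor, a higher number a weaker inhibitor), compound 1 gives > 400 ug/mL, which is a limit of the assay and not a number.
Compound 2, `O=C1O[C@@H](CN2CCC(c3ccc(F)cc3)CC2)CN1c1ccc(-n2cc(-c3ccccn3)cn2)c(F)c1`. In this assay compound 2 gives > 400 ug/mL, again a limit.
Compound 3, `O=C1CCC(=O)N1C[C@H]1CN(c2ccc(-n3cc(-c4ccccn4)cn3)c(F)c2)C(=O)O1`. In this assay compound 3 gives > 400 ug/mL, also a limit.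

Compound 1 therefore stands only at a limit in this assay, and the two other values shown are limits as well, so no ordering among the three can be read. The unmeasured compound 4, `O=C1CSC(=O)N1C[C@H]1CN(c2ccc(-n3cc(-c4ccccn4)cn3)c(F)c2)C(=O)O1`, differs from compound 1 by 2,4-dioxo-1,3-thiazolidin-3-yl in place of piperidin-1-yl on a saturated chain carbon bound to a saturated ring carbon. Two measured steps from compound 1 bear on this change: a step that the two limits leave unreadable from compound 1 to compound 2 and a step that the two limits leave unreadable from compound 1 to compound 3. Neither step has a readable size, because of the limit of > 400 ug/mL in this assay, at which 3 of the 3 values shown sit. The step to compound 3, which also exchanges the piperidin-1-yl for a cyclic imide, is the closer analogue of the present change. For the measured compounds named here, the author therefore expects no step readable in this assay for compound 4 either, and expects a step that the limit leaves unreadable from compound 1 to compound 4 to stay within the limit. Compound 4 is estimated at 500 ug/mL, with a range from 250 ug/mL to 1500 ug/mL.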

Compound 4, half-maximal inhibitory concentration: 283 ug/mL
For compound 4 the middle estimate is 1.8-fold (0.25 log units) above the measured one; low and high end bracket the measured number.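

Placing 2,4-dioxo-1,3-thiazolidin-3-yl in place of piperidin-1-yl on a saturated chain carbon bound to a saturated ring carbon gives the first actual number in this assay, with an at least 1.4-fold lower number from compound 1 to compound 4 (0.15 log units; that floor lies within the scatter). The 2,5-dioxopyrrolidin-1-yl group at the same place had not given a number, so exchanging it for 2,4-dioxo-1,3-thiazolidin-3-yl shows that the two five-membered rings need not behave alike here, with an at least 1.4-fold lower number from compound 3 to compound 4 (0.15 log units; that floor lies within the scatter). These steps are floors only, and the other steps cannot be read at all, because the comparison rests on a limit: the limit of > 400 ug/mL in this assay, at which 3 of the 4 values shown sit.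

The compounds shown leave open whether a number also appears with 2,4-dioxo-1,3-oxazolidin-3-yl, which carries oxygen in place of the ring sulfur. They also leave open what morpholin-4-yl would give at this place.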